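The source may hold more compounds than are shown below. What is called first, only, known or untested is meant among the compounds shown, and "the series" means these compounds.

Measured compounds:
Compound 1, `COc1ccc(C2=C(c3ccc(Cl)cc3)C(=O)N3CCCC3C2)cc1`: 13000 nM
Compound 2, `COc1ccc(C2=C(c3ccc(OC)cc3)C(=O)N3CCCC3C2)cc1`: 3200 nM

For the measured compounds named here, in a functional assay on HCT-116 cells (Homo sapiens) for cytotoxicity, with a stated time of 48 h (on this read-out lower numbers stand for stronger inhibition and higher numbers for weaker inhibition), compound 2 stands at the lowest of the two numbers; the only other measurement is that of compound 1, which lies higher, and the single step between them, a 4.1-fold lower number from compound 1 to compound 2 (0.61 log units; beyond the scatter), is modest but beyond the scatter.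

Compound 3, `COc1ccc(C2=C(c3ccc(C)cc3)C(=O)N3CCCC3C2)cc1`, differs from compound 2 by methyl in place of methoxy on an aromatic carbon. The measured step from compound 1 to compound 2 bears on this position: the exchange of chloro for methoxy there lowered the number by a 4.1-fold lower number from compound 1 to compound 2 (0.61 log units; beyond the scatter), so the measured pair shows that this ring position does influence the read-out. Going by the values given here, no measured step involves methyl, so the direction for compound 3 rests only on the methoxy group leaving, which removes the substituent that gave the lower number. Compound 3 is therefore expected to return part of the way toward compound 1, a step of a 1.7-fold higher number from compound 2 to compound 3 (0.24 log units; within the scatter) relative to compound 2. The estimate for compound 3 is 5500 nM, with a range from 2000 nM to 15000 nM.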

Compound 3, half-maximal inhibitory concentration: 10000 nM
Estimate against measurement, compound 3: 1.8-fold (0.26 log units) below, within the range that was stated.
By their numbers in this assay, from the lowest: compound 2; then compounds 3 and 1 (each within the scatter of the next).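

With methyl on this aromatic carbon, the low number of compound 2 is not retained: this assay records a 3.1-fold higher number from compound 2 to compound 3 (0.49 log units; beyond the scatter), a modest step. The exchange of chloro for methyl at the same place gives a 1.3-fold lower number from compound 1 to compound 3 (0.11 log units; within the scatter), which lies within the scatter, so these two groups cannot be told apart here. Among the three groups shown at this place, methoxy alone stands apart from the others, something the single step between chloro and methoxy could not show. Nothing measured here explains this difference.

The compounds shown leave open whether the gain belongs to the oxygen or to the whole methoxy group, a question on which a hydroxy group, an ethoxy group or an amine at this place would bear. They also leave open what change at the second methoxy group, shared by all three compounds, would do.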